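A Carbamoylphenyl Swap on Compound 2

A few compounds are considered here, and "the series" means these few. Any claim that something is new, unique, unknown or untested is made for them only; others in the source may bear on it.

Measured compounds:
- Compound 1 `COc1ccc([C@@H]2CC(=O)c3cc(CC=C(C)C)c(OC)cc3O2)cc1`: 58%
- Compound 2 `COc1ccc([C@@H]2C/C(=N/OCc3cn(-c4ccc(Cl)cc4C)nn3)c3cc(CC=C(C)C)c(OC)cc3O2)cc1`: 49%

In a functional assay on PC-3 cells (Homo sapiens) for inhibition, read by sulforhodamine B assay, with a stated time of 48 h, tested at 50 uM (on this read-out lower numbers stand for less inhibition of growth and higher numbers for more inhibition of growth at the one concentration tested), compound 2 gives 49% and compound 1 gives 58%. These two values lie within the usual scatter of each other, so the data do not separate them.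

Compound 3 `COc1ccc([C@@H]2C/C(=N/OCc3cn(-c4ccc(C(N)=O)cc4)nn3)c3cc(CC=C(C)C)c(OC)cc3O2)cc1` has not yet been measured. It carries 4-carbamoylphenyl in place of 4-chloro-2-methylphenyl on an aromatic nitrogen of the five-membered aromatic ring with 3 nitrogen (4-carbamoylphenyl in place of 4-chloro-2-methylphenyl on an aromatic nitrogen). Going by the values given here, no measured pair shows what a change at this place does in this assay, so the expectation starts from compound 2 at 49% and remains uncertain. No step beyond the scatter is expected, and no firm direction can be drawn from the data. The estimate is a number 3 percentage points lower from compound 2 to compound 3 (within the scatter), a step expected to stay within the scatter. For compound 3 the expected value is 46%, with an estimated range from 28% to 63%.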

Compound 3, percent growth inhibition at one concentration: 100%
Estimate against measurement, compound 3: 54 percentage points below; measured number above the stated range.
By their numbers in this assay, from the lowest: compounds 2 and 1 (each within the scatter of the next); then compound 3.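

In this assay, going by these compounds alone, the swap of 4-chloro-2-methylphenyl for 4-carbamoylphenyl on the aromatic nitrogen of the five-membered ring comes with a number 51 percentage points higher from compound 2 to compound 3 (beyond the scatter) and is the first measured change at this place. Within the data shown here, it shows that the read-out is not indifferent to the group at this position, a point that compound 1 and compound 2 could not settle, as they formed no pair differing in one place. The step also runs upward, with compound 3 at 100% in this assay, and so the larger of the two groups, the one carrying a hydrogen-bond donor and acceptor, is tolerated here at the one concentration tested.

The swap alters several features at once, so the compounds shown leave open whether the gain of the carbamoyl group or the loss of the chlorine and methyl carries the step. They also do not tell how a carboxylic acid, an amine or a plain phenyl would read at this place. No measurement given here accounts for the size of the step.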